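Flipping One Stereocentre in a Weak Inhibitor

The compounds below may be only part of what the source reports. "The series", "measured", "known", "first", "only" and "open" are said of these compounds alone.

- compound 1 `Cc1nc2ccc(CN(C)c3ccc(C(=O)N[C@@H](C[C@@H](F)C(=O)O)C(=O)O)s3)cc2c(=O)[nH]1`: 5.67 nM
- compound 2 `Nc1nc2c(c(=O)[nH]1)C[C@@H](CCc1ccc(C(=O)N[C@@H](C[C@@H](F)C(=O)O)C(=O)O)cc1)CN2`: 2300 nM

In a functional assay (T cell) with Homo sapiens as the target (on this read-out higher numbers stand for weaker inhibition and lower numbers for stronger inhibition), compound 2 gives 2300 nM, the higher of the two numbers and therefore the weaker inhibition. Compound 1 lies far lower at 5.67 nM, a gap well beyond the scatter. Compound 3 `Nc1nc2c(c(=O)[nH]1)C[C@@H](CCc1ccc(C(=O)N[C@@H](C[C@H](F)C(=O)O)C(=O)O)cc1)CN2` has the same atoms and bonds as compound 2: the two compounds have the same atoms and bonds and differ only in configuration as drawn: 1 of 3 stereo elements differ; a stereocentre at a saturated chain carbon is drawn R in compound 2 and S in compound 3. In other words, a stereocentre at a saturated chain carbon is drawn R in compound 2 and S in compound 3.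

Among the measured compounds shown here, no measured pair isolates such a change, so the size of the step is a judgement. Compound 2, at 2300 nM, sits high, and compound 1, at 5.67 nM, shows how much lower a number can go in this set. The expected change is a 5.8-fold lower number from compound 2 to compound 3 (0.76 log units; beyond the scatter), toward stronger inhibition, although a step within the scatter remains possible. For compound 3 the estimate is 400 nM, with an expected range of 30 nM to 4000 nM.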

Compound 3, half-maximal inhibitory concentration: 2300 nM
Compound 3: middle estimate off by 5.8-fold (0.76 log units), on the low side; the measured number falls inside the stated range.
By their numbers in this assay, from the lowest: compound 1; then compounds 2 and 3 (each within the scatter of the next).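

Among the compounds shown here, this is the one pair in the set that tests a single change, and it can be read cleanly: the fact that compounds 2 and 3 differ only in the configuration as drawn. In this assay, moving the stereocentre at a saturated chain carbon from R in compound 2 to S in compound 3 gives no change at the digits printed from compound 2 to compound 3 (within the scatter). For the compounds shown here, on this core, then, the configuration drawn at this carbon makes no difference that the read-out can detect, which the earlier compounds alone could not show.

From the compounds shown here alone, compound 1 gives 5.67 nM on a different core, and it has no partner with the flipped stereocentre, so whether the same flip would matter there remains open. Also open, going by these compounds, is what a hydroxyl group at this saturated chain carbon would do on either core.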